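A few compounds are considered here, and "the series" means these few. Any claim that something is new, unique, unknown or untested is made for them only; others in the source may bear on it.

Among the compounds with values here, compound 2 `Cc1cc(N2CCCCC2)c(S(C)(=O)=O)cc1C(=O)N=C(N)N` is one of two compounds measured in a functional assay for inhibition of sodium/hydrogen exchanger (Oryctolagus cuniculus); a higher number here means a weaker inhibitor, a lower number a stronger inhibitor; there compound 2 gives 21 nM, the higher of the two numbers. Within the data shown here, its nearest neighbour, compound 1 `CCCSc1cc(C)c(C(=O)N=C(N)N)cc1S(C)(=O)=O`, gives 6.8 nM in this assay, and the single step in the set, a 3.1-fold higher number from compound 1 to compound 2 (0.49 log units; beyond the scatter), runs through the same aromatic carbon that is varied next. Compound 3 `Cc1cc(-n2cccn2)c(S(C)(=O)=O)cc1C(=O)N=C(N)N` differs from compound 2 in one place: 1H-pyrazol-1-yl in place of piperidin-1-yl on an aromatic carbon. Among the measured compounds shown here, no measured pair shows this exact exchange, so the expectation rests only on the step from compound 1 to compound 2, which shows that exchanging the group on this carbon moved the number beyond the scatter while leaving it in the same region. A change of comparable size is therefore expected, its direction uncertain. Compound 3 is thus estimated at 30 nM in this assay, within a range of 8 nM to 110 nM, which corresponds to an expected step of a 1.4-fold higher number from compound 2 to compound 3 (0.15 log units; within the scatter).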

Compound 3, half-maximal inhibitory concentration: 25 nM
The estimate for compound 3 lay 1.2-fold (0.08 log units) above the measured number; the range from low to high includes it.
By their numbers in this assay, from the lowest: compound 1; then compounds 2 and 3 (each within the scatter of the next).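

In this assay, exchanging the six-membered non-aromatic ring on this aromatic carbon, ortho to the methylsulfonyl group, for a five-membered aromatic ring gives a 1.2-fold higher number from compound 2 to compound 3 (0.08 log units; within the scatter), so the two ring-bearing compounds cannot be told apart. The other exchange, a 3.7-fold higher number from compound 1 to compound 3 (0.57 log units; beyond the scatter), lies beyond the scatter, as does a 3.1-fold higher number from compound 1 to compound 2 (0.49 log units; beyond the scatter), so both ring-bearing groups give a higher number than propylsulfanyl. Among these three compounds, then, the change between the two rings matters less than the change from propylsulfanyl to either ring, although the three cannot show whether this extends to other groups.

On these data alone, whether a phenyl ring, an open-chain dimethylamino group or a methylsulfanyl group on this carbon would bring the number close to that of compound 1 remains open. Nothing available explains why the numbers fall as they do.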